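A few compounds are considered here, and "the series" means these few. Any claim that something is new, unique, unknown or untested is made for them only; others in the source may bear on it.

The measured compounds:

Compound 1, `Cc1cc(Nc2cc(-c3ccccc3)[nH]n2)n2nc(SCCCc3ccccc3)nc2n1`: in a functional assay on MCF7 cells (Homo sapiens) for inhibition, read by MTT assay, with a stated time of 72 h (on this read-out lower numbers stand for stronger inhibition and higher numbers for weaker inhibition), compound 1 gives 3900 nM.
Compound 2, `Cc1cc(Nc2cc(-c3ccccc3)[nH]n2)n2nc(SCCc3ccccc3)nc2n1`: compound 2 gives 2700 nM.
Compound 3, `Cc1cc(Nc2cc(-c3ccccc3)[nH]n2)n2nc(SCC3CC3)nc2n1`: compound 3 gives > 50000 nM, which is a limit of the assay and not a number.

Compound 3 therefore stands at the weak end of the three; it sits at the limit of > 50000 nM in this assay, at which 1 of the 3 values shown sits, the only such entry among the values shown. Between compound 1 and compound 2 the step is a 1.4-fold lower number from compound 1 to compound 2 (0.16 log units; within the scatter), so those two cannot be ordered. Compound 4, `Cc1cc(Nc2cc(-c3ccccc3)[nH]n2)n2nc(SCC(=O)c3ccccc3)nc2n1`, has not yet been measured; it differs from compound 3 by benzoyl in place of cyclopropyl on a saturated chain carbon bound to a sulfur. Going by the values given here, two measured steps bear on this change: an at least 12-fold higher number from compound 1 to compound 3 (1.10 log units; beyond the scatter) and an at least 18-fold higher number from compound 2 to compound 3 (1.26 log units; beyond the scatter), both large and both arriving at cyclopropyl. The step to compound 4 leaves cyclopropyl for a group that, like benzyl and phenethyl, carries a six-membered aromatic ring of carbon only, so a large step downward is expected, an at least 12-fold lower number from compound 3 to compound 4 (1.09 log units; beyond the scatter), bringing the number back toward those of compound 1 and compound 2. Compound 4 is estimated at 4000 nM, with a range from 1000 nM to 30000 nM.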

Compound 4, half-maximal inhibitory concentration: 5240 nM
Compound 4: middle estimate off by 1.3-fold (0.12 log units), on the low side; the measured number falls inside the stated range.
By their numbers in this assay, from the lowest: compounds 2, 1 and 4 (each within the scatter of the next). At a limit, above all of these: compound 3.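

In this assay, going by these compounds alone, the step to benzoyl on a saturated chain carbon bound to a sulfur is an at least 9.5-fold lower number from compound 3 to compound 4 (0.97 log units; beyond the scatter), so a six-membered aromatic ring of carbon only again goes with the stronger numbers, now with a carbonyl in the chain, which the benzyl and phenethyl groups of the earlier compounds could not show. Compound 3 remains a limit of the assay and not a number, so this step has only a bound: the limit of > 50000 nM in this assay, at which 1 of the 4 values shown sits. Set against the chains without a carbonyl, the steps are a 1.9-fold higher number from compound 2 to compound 4 (0.29 log units; within the scatter) and a 1.3-fold higher number from compound 1 to compound 4 (0.13 log units; within the scatter), so entering the carbonyl and its hydrogen-bond acceptor makes no readable difference at this position.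

The compounds shown leave open whether the aromatic ring itself is required, or whether a cyclohexyl group would serve as well. They also leave open how an amide or a hydroxyl in place of the carbonyl would read.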